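Hydroxy for chloro on the pyrimidine of a GIP receptor agonist

A few compounds are considered here, and "the series" means these few. Any claim that something is new, unique, unknown or untested is made for them only; others in the source may bear on it.

Measured compounds:
- compound 1, `CS(=O)(=O)c1ccc2c(c1)CCN2c1ncnc2c(C3CCN(c4ncccn4)CC3)coc12`: 196%
- compound 2, `COc1cnc(N2CCC(c3coc4c(N5CCc6cc(S(C)(=O)=O)ccc65)ncnc34)CC2)nc1`: 186%
- compound 3, `CS(=O)(=O)c1ccc2c(c1)CCN2c1ncnc2c(C3CCN(c4ncc(Cl)cn4)CC3)coc12`: 117%

All three share one core and differ only in the group on the pyrimidine ring. In a functional assay on cells for agonist activity at Glucose-dependent insulinotropic receptor (Homo sapiens), read by a luciferase reporter, with a stated time of 4 h (on this read-out lower numbers stand for smaller maximal responses and higher numbers for larger maximal responses), compound 3 stands lowest of the three. The two steps leading to it were both large: a number 79 percentage points lower from compound 1 to compound 3 (beyond the scatter) and a number 69 percentage points lower from compound 2 to compound 3 (beyond the scatter). By contrast a number 10 percentage points lower from compound 1 to compound 2 (within the scatter), so a methoxy and a hydrogen at this place gave maximal responses within the scatter of each other, while the chloro lowered the response far beyond it.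

Compound 4, `CS(=O)(=O)c1ccc2c(c1)CCN2c1ncnc2c(C3CCN(c4ncc(O)cn4)CC3)coc12`, has not yet been measured. It differs from compound 3 in one place: hydroxy in place of chloro on an aromatic carbon. For the measured compounds named here, the steps that bear on this change are the two that put the chloro in, since compound 4 takes the chloro out again. The hydroxy that enters is, like the methoxy of compound 2, a group with a single oxygen heavy atom. An upward step beyond the scatter is therefore expected, and the estimated step in this assay is a number 53 percentage points higher from compound 3 to compound 4 (beyond the scatter). For compound 4 the expected maximal response is 170%, with a range from 120% to 205%.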

Compound 4, largest response reached (Emax), in percent of the reference or control that the assay uses: 145%
Compound 4: middle estimate off by 25 percentage points, on the high side; the measured number falls inside the stated range.
By their numbers in this assay, from the lowest: compound 3; then compound 4; then compounds 2 and 1 (each within the scatter of the next).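

In this assay, the change from 5-chloropyrimidin-2-yl to 5-hydroxypyrimidin-2-yl restores only part of the response that separates the chloro compound from the others: the result is a number 28 percentage points higher from compound 3 to compound 4 (beyond the scatter), yet the unsubstituted parent remains clearly ahead, with a number 51 percentage points lower from compound 1 to compound 4 (beyond the scatter) in the other direction. Hydrogen and methoxy had given responses within the scatter of each other, so this position might have seemed to tolerate an oxygen substituent, but removing only the methyl from the methoxy oxygen gives a number 41 percentage points lower from compound 2 to compound 4 (beyond the scatter), showing that the single oxygen atom does not by itself set the response here. At this place, therefore, the chloro and hydroxy compounds both stand beyond the scatter below hydrogen and methoxy, and a small change on the oxygen matters as much as the swap of chloro for hydroxy. No measurement shown accounts for this order.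

On these data alone, it remains open where an amine, a carboxylic acid, a fluoro or a longer chain such as ethoxy would fall at this position, and whether any of them would join hydrogen and methoxy. The compounds shown also leave open whether the same order would hold on a different core or in any read-out other than the maximal response in this assay on this core.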